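From a Silicon-Bearing Group to Diethylcarbamoyl

The source may hold more compounds than are shown below. What is called first, only, known or untested is meant among the compounds shown, and "the series" means these compounds.

In a functional assay on SW480 cells (Homo sapiens) for antiproliferative activity, read by MTT assay, with a stated time of 48 h (on this read-out higher numbers stand for weaker inhibition and lower numbers for stronger inhibition), compound 1 `CC[Si](CC)(CC)C/C1=C/C[C@](C)(CCC=C(C)C)/C=C/[C@@H](OC(=O)C=C(C)C)[C@](C)(O)/C=C/C1=O` gives 2690 nM, the middle of three measured numbers. Compound 2 `CC(C)=CCC[C@]1(C)/C=C/[C@@H](OC(=O)C=C(C)C)[C@](C)(O)/C=C/C(=O)/C(COC(=O)c2ccc([N+](=O)[O-])cc2)=C\C1` gives the lowest number, 570 nM, and compound 3 `CC(C)=CCC[C@](C)(/C=C/[C@@H](OC(=O)C=C(C)C)[C@](C)(O)/C=C/C(=O)/C=C/N1CCN(C)CC1)CC=O` gives the highest, 12400 nM.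

Compound 4 `CCN(CC)C(=O)/C1=C/C[C@](C)(CCC=C(C)C)/C=C/[C@@H](OC(=O)C=C(C)C)[C@](C)(O)/C=C/C1=O` has not yet been measured. It differs from compound 1 in one place: a group of 7 heavy atoms (5 carbon, 1 nitrogen, 1 oxygen; no ring) in place of a group of 8 heavy atoms (7 carbon, 1 silicon; no ring), on a double-bonded ring carbon. A silicon-bearing group thus gives way to diethylcarbamoyl on a double-bonded ring carbon.

For the measured compounds named here, only one measured step bears on this change: a 4.7-fold lower number from compound 1 to compound 2 (0.67 log units; beyond the scatter). That modest step also replaced silicon-bearing atoms at this part of the molecule, but the group it introduced contains an aromatic ring, whereas diethylcarbamoyl has none. Compound 3 differs from compound 1 in more than one place, so it offers no clean comparison. Going by the values given here, no measured compound carries diethylcarbamoyl, so the direction of any change remains uncertain.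

Only a small shift is therefore expected, with a slight lean towards a lower number and no clear move beyond the scatter. The expected change is a 1.2-fold lower number from compound 1 to compound 4 (0.09 log units; within the scatter). For compound 4 the estimated value is 2200 nM, with an expected range from 650 nM to 7500 nM.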

Compound 4, half-maximal inhibitory concentration: 11700 nM
Estimate against measurement, compound 4: 5.3-fold (0.73 log units) below; the measured number lies above the stated range.
By their numbers in this assay, from the lowest: compound 2; then compound 1; then compounds 4 and 3 (each within the scatter of the next).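

In this assay, the change from the silicon-bearing group to diethylcarbamoyl gives a 4.3-fold higher number from compound 1 to compound 4 (0.64 log units; beyond the scatter) and so shows that this part of the molecule does not tolerate every replacement equally. Set beside a 4.7-fold lower number from compound 1 to compound 2 (0.67 log units; beyond the scatter) as the only earlier step here, it shows that changes in this region of compound 1 can move the number in either direction, whereas that earlier step had shown only a fall. No measurement at hand accounts for this rise.

The two steps also differ in attachment, since the group in compound 2 is carried on a saturated chain carbon bound to the double-bonded ring carbon, while diethylcarbamoyl sits on the ring carbon itself, so the compounds shown leave open whether the attachment or the group governs the number. A diethylcarbamoylmethyl group, with that saturated chain carbon restored, would bear on this question, while a smaller dimethylcarbamoyl group or a carboxylic acid on the same ring carbon would show how far the result extends beyond diethylcarbamoyl.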